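Hydroxyphenyl replacement on the thioether arm of compound 3

The source may report more compounds than this note shows. Statements on the series, on what has been measured and on what is new or still open speak of the compounds shown alone.

Measured so far in an assay on isolated protein for inhibition of Retinaldehyde dehydrogenase 3 (Homo sapiens); on this read-out higher numbers stand for weaker inhibition and lower numbers for stronger inhibition:
compound 1 `CC(C)C(Sc1nc2c(cnn2C)c(=O)n1-c1ccccc1)c1ccccc1` gives 130 nM
compound 2 `Cn1ccc2c(=O)n(-c3ccccc3)c(SCc3cccc(F)c3)nc21` gives 600 nM
compound 3 `CCC(Sc1nc2c(cnn2C)c(=O)n1-c1ccccc1)c1ccccc1` gives 119 nM

Compound 3 holds the lowest of the three numbers; compound 1 sits nearest, within the scatter, and compound 2 furthest, beyond it. Compound 4 `CC(Sc1nc2c(cnn2C)c(=O)n1-c1ccccc1)c1cccc(O)c1` differs from compound 3 in a group of 9 heavy atoms (8 carbon, 1 oxygen; one six-membered aromatic ring of carbon only) in place of a group of 9 heavy atoms (9 carbon; one six-membered aromatic ring of carbon only), on a sulfur. Going by the values given here, the only single-point step measured, a 1.1-fold lower number from compound 1 to compound 3 (0.04 log units; within the scatter), bears on it indirectly: trimming the saturated chain moved the number little. Among the compounds with values here, no measured step introduces a hydroxyl on the pendant ring, and compound 2 differs from compound 3 in more than one place, so its higher number cannot be assigned to any single change. The expected step in this assay is therefore small, in no clear direction. For compound 4 the estimate is 160 nM, with a range from 60 nM to 450 nM. The step this estimate implies, a 1.3-fold higher number from compound 3 to compound 4 (0.13 log units; within the scatter), is expected to stay within the scatter.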

Compound 4, half-maximal inhibitory concentration: 91 nM
Compound 4: middle estimate off by 1.8-fold (0.25 log units), on the high side; measured number inside the range.
By their numbers in this assay, from the lowest: compounds 4, 3 and 1 (each within the scatter of the next); then compound 2.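

In this assay, the swap of 1-phenylpropyl for the hydroxyl-bearing group on the sulfur gives a 1.3-fold lower number from compound 3 to compound 4 (0.12 log units; within the scatter). This position therefore takes a group with a hydrogen-bond donor and a hydrogen-bond acceptor, where compound 3 has neither, with no change readable beyond the scatter. No measured evidence bears on the reason for this result.

The group swap alters the saturated chain and the ring together, so the share of the hydroxyl alone cannot be read. On these data alone, whether an amine or a carboxylic acid on that ring would hold the number in this range remains open.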